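Swapping a Methoxyphenyl for a Fluorophenyl on the Amide

The compounds below may be only part of what the source reports. "The series", "measured", "known", "first", "only" and "open" are said of these compounds alone.

Going by the values given here, compound 1 `CCOC(=O)C1=Cc2ccccc2OC1(OCc1cn(CC(=O)Nc2ccc(OC)cc2)nn1)C(F)(F)F` is the one compound here with a number in a functional assay on HeLa cells (Homo sapiens) for inhibition, read by MTT assay, with a stated time of 24 h (on this read-out higher numbers stand for weaker inhibition and lower numbers for stronger inhibition), where compound 1 gives 31900 nM. Compound 2 `O=C(O)C1=Cc2ccccc2OC1(OCc1cc(-c2ccc(F)cc2)no1)C(F)(F)F` reaches only a limit of this assay, > 150000 nM, which is not a number. That limit is where one of the two values sits (the limit of > 150000 nM in this assay, at which 1 of the 2 values shown sits). Compound 3 `CCOC(=O)C1=Cc2ccccc2OC1(OCc1cn(CC(=O)Nc2cccc(F)c2)nn1)C(F)(F)F` differs from compound 1 in one place: 3-fluorophenyl in place of 4-methoxyphenyl on an amide-type nitrogen. Among the compounds with values here, no measured pair shows a step of this kind. The expected step of a 1.0-fold higher number from compound 1 to compound 3 (0.00 log units; within the scatter) is therefore small, within the usual scatter. Compound 3 is estimated at 32000 nM, in the range 10000 nM to 100000 nM.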

Compound 3, half-maximal inhibitory concentration: > 150000 nM
Compound 3 gave a limit, no number; the forecaster's own chance of this, stated with the estimate: 25%; middle value at least 4.6-fold (0.67 log units) from the limit.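

Compared with the earlier compounds, this pair shows that the group on the amide-type nitrogen matters: 3-fluorophenyl in place of 4-methoxyphenyl gives an at least 4.7-fold higher number from compound 1 to compound 3 (0.67 log units; beyond the scatter) in this assay, meaning weaker inhibition. Compound 3 stands at a limit and not at a number, so the step gives only the smallest possible size of the change, and the limit recurs in this small set: the limit of > 150000 nM in this assay, at which 2 of the 3 values shown sit.

The compounds shown leave open whether losing the methoxy group or gaining the fluorine matters more. A plain phenyl on that nitrogen would help separate the two.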